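A few compounds are considered here, and "the series" means these few. Any claim that something is new, unique, unknown or untested is made for them only; others in the source may bear on it.

Working notes on the series. In an in vitro ADME assay on microsomes (Mus musculus) for metabolic stability (a higher number here means that the compound lasts longer, a lower number that the compound disappears faster), compound 1 (`CNC(=O)Nc1ccc(-c2nc(N3CC4CCC(C3)O4)c3cnn(C)c3n2)cc1`) gives > 0.5 h as a limit of the assay, not a number. Compound 2 (`O=C(Nc1ccccc1)Nc1ccc(-c2nc(N3CC4CCC(C3)O4)c3cnn(C4CCC5(CC4)OCCO5)c3n2)cc1`) gives > 0.5 h as a limit too, so its standing is known only as a limit. The evidence so far is the limit of > 0.5 h in this assay, at which 2 of the 2 values shown sit, and no exact half-life is in hand.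

Compound 3 (`CCNC(=O)Nc1ccc(-c2nc(N3CC4CCC(C3)O4)c3cnn(C4CCC5(CC4)OCCO5)c3n2)cc1`) has ethyl in place of phenyl on an amide-type nitrogen, counted as ethyl in place of phenyl on an amide-type nitrogen and also readable as anilino to ethylamino. No measured step sizes this change, and compound 2, reported as the limit > 0.5 h in this assay, gives no direction, so no shift beyond the scatter is expected. The estimated step that the limit leaves unreadable from compound 2 to compound 3 is expected to stay within the scatter. For compound 3 the expected half-life is 0.7 h as the estimate, with an expected range of 0.35 h to 1.5 h in this estimate, and another limit is a likely report.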

Compound 3, half-life: 0.45 h
Compound 3: the middle estimate sits 1.6-fold (0.19 log units) above what was measured; measured number inside the range.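

Compound 3 gives the series its first exact half-life in this assay: compound 3 stands at 0.45 h, so substitution on this amide-type nitrogen can now be read against a number. Ethyl in place of phenyl at this place gives an at least 1.1-fold lower number from compound 2 to compound 3 (0.04 log units; that floor lies within the scatter), so the printed floor supports no claim of a real change. The true size of the step stays unread because compound 2 is held only as a limit of the assay: the limit of > 0.5 h in this assay, at which 2 of the 3 values shown sit.

The compounds shown leave open how a longer chain such as butyl, or a chain carrying an amine, would read on this nitrogen against compound 3. Also open, as far as these compounds go, is whether the step from phenyl to ethyl would hold on another core.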